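This account rests on a few compounds, and the source may have more. Where it says the series, first, only, none or still open, it means among the compounds named here.

Measured compounds:
Compound 1 `Cc1ccc(Cn2cc(CNC(=O)c3cnc(Nc4ccc(C#N)cc4)cc3Oc3c(C)cc(C)cc3C)nn2)cc1` gives 165000 nM in an ADME assay on MT4 cells (Homo sapiens) for cytotoxicity, read by MTT assay, with a stated time of 5 days; on this read-out lower numbers stand for higher toxicity in this test and higher numbers for lower toxicity in this test.
Compound 2 `Cc1cc(C)c(Oc2cc(Nc3ccc(C#N)cc3)ncc2C(=O)NCc2cn(Cc3ccccc3C#N)nn2)c(C)c1` reaches only a limit of this assay, > 219000 nM.

Among the two values, compound 1 holds the only actual number; the other is a limit. Compound 3 `Cc1cc(C)c(Oc2cc(Nc3ccc(C#N)cc3)ncc2C(=O)NCc2cn(Cc3cccc(F)c3)nn2)c(C)c1` differs from compound 1 by 3-fluorophenyl in place of 4-methylphenyl on a saturated chain carbon bound to an aromatic nitrogen. For the measured compounds named here, the single measured step that bears on this change, an at least 1.3-fold higher number from compound 1 to compound 2 (0.12 log units; that floor lies within the scatter), swaps a group at the same place and stays within the scatter. For compound 3 a step no larger than the scatter is therefore expected, a 1.1-fold higher number from compound 1 to compound 3 (0.04 log units; within the scatter). Compound 3 is estimated at 180000 nM, with a range from 100000 nM to 330000 nM.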

Compound 3, half-maximal cytotoxic concentration: >= 204000 nM
Compound 3 was reported as a limit (the forecaster's own chance of this, stated with the estimate: 35%); at least 1.1-fold (0.05 log units) between middle value and limit.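

Compound 3 joins compound 2 in reaching a limit rather than a number in this assay: the limit of >= 204000 nM in this assay, at which 1 of the 3 values shown sits. Replacing 4-methylbenzyl with 3-fluorobenzyl gives an at least 1.2-fold higher number from compound 1 to compound 3 (0.09 log units; that floor lies within the scatter), so a second group at this place also shows no change beyond the scatter. Compound 2 and compound 3 both stand at limits, so the step between them cannot be read.

Going by these compounds, how far the true values lie past these limits stays open. So does the read-out with a carboxylic acid or an amine on the phenyl ring at this place.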